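Trimming a para substituent on the aryl-pyridine tail

The source may hold more compounds than are shown below. What is called first, only, known or untested is meant among the compounds shown, and "the series" means these compounds.

Three compounds share a core in which an amide joins a quinoline to a pyridine that carries a further aromatic ring. Compound 1 `O=C(Nc1ccc2cccnc2c1)c1ccc(-c2ccccc2F)nc1` carries a 2-fluorophenyl on that pyridine, and in an in vitro functional assay on 1321-N1 cells for antagonist activity at transient receptor potential cation channel subfamily V member 1 (Homo sapiens), read by FLIPR and calcium flux (a lower number here means a less potent compound, a higher number a more potent compound, by a factor of ten per unit of this negative logarithm), compound 1 gives 8.7. Compound 2 `N#Cc1ccc(C(=O)Nc2ccc3cccnc3c2)cn1` has a cyano in place of the 2-fluorophenyl; the measurement for compound 2 in this assay is only a limit, < 6.7, and so the step of a number at least 2.00 log units lower from compound 1 to compound 2 (beyond the scatter) is known only as a floor (the limit of < 6.7 in this assay, at which 1 of the 3 values shown sits). Compound 3 `O=C(Nc1ccc2cccnc2c1)c1ccc(-c2ccc(C(F)(F)F)cc2)nc1` carries a trifluoromethyl on the outer phenyl, and in this assay compound 3 gives 7.3, the lowest of the two numbers and beyond the scatter below compound 1.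

Compound 4 `O=C(Nc1ccc2cccnc2c1)c1ccc(-c2ccc(F)cc2)nc1` differs from compound 3 by fluoro in place of trifluoromethyl on an aromatic carbon. Within the data shown here, no measured step here changes that position, so the only guide is that compound 1 and compound 3, which both keep the outer ring, lie between a high and a moderate number. Compound 4 is expected to land between them, a step of a number 0.70 log units higher from compound 3 to compound 4 (beyond the scatter) upward, at an estimated 8 with a range from 7.3 to 8.7.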

Compound 4, negative logarithm of the antagonist equilibrium constant: 8.2
Estimate against measurement, compound 4: 0.20 log units below; the measured number falls inside the stated range.
By their numbers in this assay, from the lowest: compound 3; then compound 4; then compound 1. At a limit, below all of these: compound 2.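

On the outer phenyl, the group at this place clearly matters: in this assay, fluoro in place of trifluoromethyl gives a number 0.90 log units higher from compound 3 to compound 4 (beyond the scatter). The place of the fluoro on that ring counts as well, since 4-fluorophenyl in place of 2-fluorophenyl gives a number 0.50 log units lower from compound 1 to compound 4 (beyond the scatter). Replacing cyano with 4-fluorophenyl gives a number at least 1.50 log units higher from compound 2 to compound 4 (beyond the scatter), a step known only as a floor, since compound 2 has a limit of the assay and not a number: the limit of < 6.7 in this assay, at which 1 of the 4 values shown sits.

With only fluoro and trifluoromethyl shown at this place on the outer phenyl, the compounds cannot say how a methyl, a methoxy or an amine there would read. They also leave open why fluoro reads higher than trifluoromethyl here.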